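This account rests on a few compounds, and the source may have more. Where it says the series, first, only, none or still open, it means among the compounds named here.

Compound 1, `CN1CCN(CCCS(=O)(=O)c2ccc3nc(NC(=O)NC(=O)c4cc(-n5cccn5)ccc4Cl)sc3c2)CC1`, gives 0.67 nM in an assay on HEK293 cells for displacement of a labelled ligand from growth hormone secretagogue receptor type 1 (Homo sapiens), with a stated time of 60 min; on this read-out higher numbers stand for weaker inhibition and lower numbers for stronger inhibition.
Compound 2, `Cc1ccn(-c2ccc(Cl)c(C(=O)NC(=O)Nc3nc4ccc(S(=O)(=O)CCCN5CCN(C)CC5)cc4s3)c2)n1`, gives 0.53 nM in this assay.

Within the data shown here, compound 1 and compound 2 lie within the scatter of each other; the change between them, a 1.3-fold lower number from compound 1 to compound 2 (0.10 log units; within the scatter), is the only measured step. Compound 3, `COc1cc(Cl)c(C(=O)NC(=O)Nc2nc3ccc(S(=O)(=O)CCCN4CCN(C)CC4)cc3s2)cc1-n1cccn1`, differs from compound 1 by methoxy in place of hydrogen on an aromatic carbon. Among the measured compounds shown here, no measured step touches this place or this group; the one step available, on another aromatic carbon, stayed within the scatter. A step of a 1.0-fold higher number from compound 1 to compound 3 (0.02 log units; within the scatter) is therefore expected, that is none beyond the scatter. Compound 3 is estimated at 0.7 nM, with a range from 0.3 nM to 1.8 nM.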

Compound 3, half-maximal inhibitory concentration: 0.62 nM
The estimate for compound 3 lay 1.1-fold (0.05 log units) above the measured number; measured number inside the range.
By their numbers in this assay, from the lowest: compounds 2, 3 and 1 (each within the scatter of the next).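

Methoxy in place of hydrogen, on the aromatic carbon ortho to the 1H-pyrazol-1-yl group and para to a large group, gives a step within the scatter in this assay (a 1.1-fold lower number from compound 1 to compound 3 (0.03 log units; within the scatter)). Among these compounds, this is the first measured change at this place, and it shows that methoxy, with its 2 heavy atoms and 1 hydrogen-bond acceptor, is accommodated here without a shift beyond the scatter. No supporting data are available to explain this result. The compounds shown leave open whether an amine or a carboxylic acid at this place would also stay within the scatter. They also leave open whether methoxy would give the same result on the other aromatic carbons of this ring.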